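The source may hold more compounds than are shown below. What is called first, only, known or untested is meant among the compounds shown, and "the series" means these compounds.

Measured so far in a functional assay on LNCaP cells (Homo sapiens) for cytotoxicity, read by MTT assay, with a stated time of 48 h; on this read-out lower numbers stand for stronger inhibition and higher numbers for weaker inhibition:
Compound 1, `Cn1cc(/C=C2/C(=O)Nc3ccccc32)c2cc(Nc3nccc(-c4ccccc4)n3)ccc21`, gives 13400 nM.
Compound 2, `Cc1ccc(-c2ccnc(Nc3ccc4c(c3)c(/C=C3/C(=O)Nc5ccccc53)cn4C)n2)cc1`, gives only the limit > 100000 nM.
Compound 3, `COc1ccc(-c2ccnc(Nc3ccc4c(c3)c(/C=C3/C(=O)Nc5ccccc53)cn4C)n2)cc1`, gives only the limit > 100000 nM.

Compound 3 stands at the limit of this assay (the limit of > 100000 nM in this assay, at which 2 of the 3 values shown sit) and so has no number of its own; its standing against compound 1 is read from the step alone. The change to compound 4, `Cn1cc(/C=C2/C(=O)Nc3ccccc32)c2cc(Nc3nccc(-c4ccc(O)cc4)n3)ccc21`, is hydrogen in place of methyl on an oxygen on an aromatic ring. Among the compounds with values here, no measured pair carries a hydroxy, so no step addresses it directly. What is known: an at least 7.4-fold higher number from compound 1 to compound 3 (0.87 log units; beyond the scatter) and an at least 7.4-fold higher number from compound 1 to compound 2 (0.87 log units; beyond the scatter), each a loss on placing a group on the phenyl, while a step that the two limits leave unreadable from compound 2 to compound 3 is left unreadable by the two limits. The hydroxy is again a group on that phenyl, so a number near the limit is the closest guide; removing the methyl carries compound 4 partway back toward compound 1 in structure, yet nothing measured says whether the loss is tied to the methyl itself or to any group being present there. Compound 4 is therefore expected near or somewhat below the limit, with the estimate 50000 nM and a range from 8000 nM to 200000 nM. The estimated step is an at least 2.0-fold lower number from compound 3 to compound 4 (0.30 log units; that floor lies within the scatter).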

Compound 4, half-maximal inhibitory concentration: 10800 nM
For compound 4 the middle estimate is 4.6-fold (0.67 log units) above the measured one, and the stated range covers the measured number.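

In this assay, a group on the phenyl does not by itself cost activity at this position: a 1.2-fold lower number from compound 1 to compound 4 (0.09 log units; within the scatter), so 4-hydroxyphenyl and the unsubstituted phenyl of compound 1 cannot be told apart here. The loss depends on which group is present, and a single methyl on the oxygen separates a measurable reading from one with no number of its own, with an at least 9.2-fold lower number from compound 3 to compound 4 (0.96 log units; beyond the scatter). The hydroxy also stands clear of the methyl on the aromatic carbon, with an at least 9.2-fold lower number from compound 2 to compound 4 (0.96 log units; beyond the scatter), so among these four compounds the loss goes with methyl and methoxy and not with every group placed on this ring.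

How methyl and methoxy rank against each other cannot be read, since compound 2 and compound 3 each give only a limit: the limit of > 100000 nM in this assay, at which 2 of the 4 values shown sit. As far as these compounds go, whether the hydrogen on the oxygen is what keeps the reading at the level of compound 1 also stays open, and an amine or a carboxylic acid in place of the hydroxy would show whether other groups on this phenyl read like the hydroxy or like methoxy.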